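Para-substituent change on the thioaryl group of compound 2

The source may report more compounds than this note shows. Statements on the series, on what has been measured and on what is new or still open speak of the compounds shown alone.

Of the compounds shown here, two have been measured so far. Compound 1 `OC[C@H]1O[C@@H](n2cnc3c(CSc4ccccc4F)ncnc32)[C@H](O)[C@@H]1O` gives 355 nM in an assay on isolated protein for binding affinity to Equilibrative nucleoside transporter 1 (Homo sapiens); a higher number here means a weaker inhibitor, a lower number a stronger inhibitor. Within the data shown here, compound 2 `OC[C@H]1O[C@@H](n2cnc3c(CSc4ccc(Br)cc4)ncnc32)[C@H](O)[C@@H]1O` gives 178 nM in this assay, and it stands at the lower of the two numbers, with compound 1 as its only neighbour; the step of a 2.0-fold lower number from compound 1 to compound 2 (0.30 log units; within the scatter) does not separate the two beyond the scatter.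

Compound 3 `COC(=O)c1ccc(SCc2ncnc3c2ncn3[C@@H]2O[C@H](CO)[C@@H](O)[C@H]2O)cc1` is not yet measured. It differs from compound 2 in one place: methoxycarbonyl in place of bromo on an aromatic carbon, on a six-membered aromatic ring of carbon only, para to a large group.

Among the measured compounds shown here, only one measured step exists, from compound 1 to compound 2, and it concerns the same aryl ring but a different substituent pattern; it was within the scatter. For the measured compounds named here, no measured step addresses a methoxycarbonyl group or any change at this position, so the series gives no direction for the new group. Going by the values given here, the single step on the aryl ring being small, a step no larger than the scatter is the working expectation in this assay, though the uncertainty is wide.

For compound 3 the estimated value in this assay is 250 nM, with a range from 80 nM to 800 nM, which corresponds to an expected step of a 1.4-fold higher number from compound 2 to compound 3 (0.15 log units; within the scatter).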

Compound 3, half-maximal inhibitory concentration: 813 nM
Compound 3: middle estimate off by 3.3-fold (0.51 log units), on the low side; measured number above the stated range.
By their numbers in this assay, from the lowest: compounds 2 and 1 (each within the scatter of the next); then compound 3.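

In this assay, among these compounds, the substituent at this place, on an aromatic carbon para to a large group, does make a difference: methoxycarbonyl in place of bromo gives the first step beyond the scatter (a 4.6-fold higher number from compound 2 to compound 3 (0.66 log units; beyond the scatter)). The 4-(methoxycarbonyl)phenyl compound also separates from the 2-fluorophenyl compound (a 2.3-fold higher number from compound 1 to compound 3 (0.36 log units; beyond the scatter)), whereas the earlier step between the two aryl groups stayed within the scatter, so the aryl group on the sulfur is not a freely interchangeable part of the series. The exchange alters both the heavy atoms and the hydrogen-bond acceptors at once, and no measurement at hand bears on the reason for the higher number.

From the compounds shown here alone, whether the higher number belongs to methoxycarbonyl alone or extends to other groups at this place remains open; a carboxylic acid, a primary amide, a nitrile or a methyl group at the same carbon would help to show this. Also open, going by these compounds, is whether an unsubstituted phenyl ring sits nearer to the bromo compound or to the methoxycarbonyl compound.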